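Working notes: 4-fluorophenyl to 2,4,6-trichlorophenyl

The source may report more compounds than this note shows. Statements on the series, on what has been measured and on what is new or still open speak of the compounds shown alone.

Measured in a functional assay on MCF7 cells (Homo sapiens) for inhibition, read by sulforhodamine B assay, with a stated time of 48 h; on this read-out lower numbers stand for stronger inhibition of growth and higher numbers for weaker inhibition of growth:
- compound 1 `Fc1ccc(Cn2cc(CCCOc3cccc4cccnc34)nn2)cc1`: 11.7 ug/mL
- compound 2 `Brc1ccc(Cn2cc(CCCOc3cccc4cccnc34)nn2)cc1`: 28 ug/mL

Among the compounds with values here, compound 1 holds the lower of the two numbers, which means the stronger inhibition of growth, and compound 2 is its only comparison. Compound 3 `Clc1cc(Cl)c(Cn2cc(CCCOc3cccc4cccnc34)nn2)c(Cl)c1` has not yet been measured. It carries 2,4,6-trichlorophenyl in place of 4-fluorophenyl on a saturated chain carbon bound to an aromatic nitrogen.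

Within the data shown here, one measured step bears on this change: a 2.4-fold higher number from compound 1 to compound 2 (0.38 log units; beyond the scatter), with bromo in place of fluoro on an aromatic carbon. Among the measured compounds shown here, no measured compound carries a 2,4,6-trichlorophenyl group, so this single step is a thin guide. A modest move to a higher number in this assay is expected, of similar size. The expected step is a 2.1-fold higher number from compound 1 to compound 3 (0.31 log units; beyond the scatter). For compound 3 the estimate is 24 ug/mL, with an expected range of 10 ug/mL to 55 ug/mL.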

Compound 3, concentration for 50% growth inhibition: 2.9 ug/mL
For compound 3 the middle estimate is 8.3-fold (0.92 log units) above the measured one; measured number outside the range, below it.
By their numbers in this assay, from the lowest: compound 3; then compound 1; then compound 2.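

In this assay, the group on the saturated chain carbon bound to an aromatic nitrogen can move the number down as well as up: 2,4,6-trichlorophenyl in place of 4-fluorophenyl gives a 4.0-fold lower number from compound 1 to compound 3 (0.61 log units; beyond the scatter), and in place of 4-bromophenyl it gives a 9.7-fold lower number from compound 2 to compound 3 (0.98 log units; beyond the scatter). The earlier bromo for fluoro step therefore does not set the direction for this position, and compound 3 now holds the lowest number, with its steps to both other compounds beyond the scatter. Nothing measured on these compounds accounts for the change.

The compounds shown leave open how an unsubstituted phenyl or a single chloro on the ring would stand against compound 3, and so whether all three chlorines are needed. Also open, on these data alone, is how a methoxy or a carboxylic acid on this ring would read.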